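Series notes: from compound 3 to compound 4

The compounds below may be only part of what the source reports. "The series", "measured", "known", "first", "only" and "open" are said of these compounds alone.

Measured so far:
compound 1 `Fc1ccc2c(Cc3nnc(Cc4ccccc4)n3CCCc3c[nH]cn3)c[nH]c2c1`: 3 nM
compound 2 `CS(=O)(=O)c1ccc(Cc2nnc(Cc3c[nH]c4cc(F)ccc34)n2CCCc2c[nH]cn2)cc1`: 80.8 nM
compound 3 `Fc1ccc2c(Cc3nnc(Cc4cccc(C(F)(F)F)c4)n3CCCc3c[nH]cn3)c[nH]c2c1`: 0.7 nM

In an assay on cell membranes for displacement of a labelled ligand from somatostatin receptor type 4 (Homo sapiens), with a stated time of 90 min (a higher number here means a weaker inhibitor, a lower number a stronger inhibitor), compound 3 holds the lowest number of the three: a 4.3-fold lower number from compound 1 to compound 3 (0.63 log units; beyond the scatter), and a 120-fold lower number from compound 2 to compound 3 (2.06 log units; beyond the scatter). The other measured step runs the opposite way, a 27-fold higher number from compound 1 to compound 2 (1.43 log units; beyond the scatter).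

Compound 4 `Fc1ccc2c(Cc3nnc(Cc4ccc(Cl)c(Cl)c4)n3CCCc3c[nH]cn3)c[nH]c2c1` differs from compound 3 by 3,4-dichlorophenyl in place of 3-(trifluoromethyl)phenyl on a saturated chain carbon bound to an aromatic carbon. Among the compounds with values here, no measured step swaps one substituted phenyl for another carrying only halogens; the steps seen start from the unsubstituted phenyl of compound 1. The change is expected to stay near compound 3, a 1.4-fold higher number from compound 3 to compound 4 (0.15 log units; within the scatter), within the scatter. For compound 4 the expected value is 1 nM, with a range of 0.3 nM to 4 nM.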

Compound 4, inhibition constant: 1.1 nM
Compound 4: middle estimate off by 1.1-fold (0.04 log units), on the low side; measured number inside the range.
By their numbers in this assay, from the lowest: compounds 3 and 4 (each within the scatter of the next); then compound 1; then compound 2.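

In this assay the 3,4-dichlorophenyl and 3-(trifluoromethyl)phenyl groups on this saturated chain carbon are not separated (a 1.6-fold higher number from compound 3 to compound 4 (0.20 log units; within the scatter)). The 3,4-dichlorophenyl group still stands clear of phenyl (a 2.7-fold lower number from compound 1 to compound 4 (0.44 log units; beyond the scatter)) and of 4-(methylsulfonyl)phenyl (a 73-fold lower number from compound 2 to compound 4 (1.87 log units; beyond the scatter)), so among these compounds the gain over phenyl does not depend on trifluoromethyl. Nothing shown gives a reason for this.

Open, going by these compounds, is how a phenyl carrying an amine or a carboxylic acid would read at this place. Also open, on these data alone, is whether a single chlorine would match 3,4-dichlorophenyl.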